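The compounds below may be only part of what the source reports. "The series", "measured", "known", "first", "only" and "open" are said of these compounds alone.

Compound 2 `Cc1ccccc1C(=O)Nc1sc2c(c1C(N)=O)CCN(C(=S)Nc1ccccc1Cl)C2` is one of two analogues measured in a functional assay on HL-60 cells (Homo sapiens) for antiproliferative activity, with a stated time of 24 h (on this read-out lower numbers stand for stronger inhibition and higher numbers for weaker inhibition), and in this assay compound 2 gives 20900 nM. That is the higher of the two numbers recorded, but its nearest neighbour, compound 1 `NC(=O)c1c(NC(=O)c2ccccc2Br)sc2c1CCN(C(=S)Nc1ccccc1Cl)C2`, sits close: in this assay compound 1 gives 14600 nM, and the step of a 1.4-fold higher number from compound 1 to compound 2 (0.16 log units; within the scatter) shows how little separates them.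

Compound 3 `COc1ccccc1C(=O)Nc1sc2c(c1C(N)=O)CCN(C(=S)Nc1ccccc1Cl)C2` has not yet been measured. It differs from compound 2 in one place: methoxy in place of methyl on an aromatic carbon. Among the compounds with values here, the only measured step that bears on this position is the one from compound 1 to compound 2, where bromo became methyl on the same aromatic carbon without moving the number beyond the scatter. With a single step of that size to go on, and with the two measured values lying so close together, there is no basis for expecting the swap of methyl for methoxy to produce a shift beyond the scatter in this assay, in either direction.

Compound 3 is therefore expected to give about 20000 nM, within a range of 8000 nM to 50000 nM, which would mean an expected step of a 1.0-fold lower number from compound 2 to compound 3 (0.02 log units; within the scatter).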

Compound 3, half-maximal inhibitory concentration: 20800 nM
Beside the measured number, compound 3's estimate is 1.0-fold (0.02 log units) below it, and the stated range covers the measured number.
By their numbers in this assay, from the lowest: compounds 1, 3 and 2 (each within the scatter of the next).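

In this assay, methoxy, which brings an oxygen and a hydrogen-bond acceptor that methyl lacks, can stand on this aromatic carbon, ortho to a large group, without moving the number beyond the scatter, with a 1.0-fold lower number from compound 2 to compound 3 (0.00 log units; within the scatter). The comparison with the bromo compound gives the same reading, with a 1.4-fold higher number from compound 1 to compound 3 (0.15 log units; within the scatter), so all three steps among these compounds now lie within the scatter and bromo, methyl and methoxy cannot be told apart at this position in this read-out. Nothing measured here offers an explanation for this lack of separation.

As far as these compounds go, the three groups tried at this position therefore mark no direction in which the number might move, and it remains open whether an amine, a carboxylic acid or a longer chain such as butoxy on the same carbon would shift it beyond the scatter. Also open, from the compounds shown here alone, is whether the number responds at all to changes elsewhere on the shared core, including the 2-chlorophenyl group that all three compounds carry unchanged.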